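Switching the arylidene substituent toward a methoxyphenyl group

A few compounds are considered here, and "the series" means these few. Any claim that something is new, unique, unknown or untested is made for them only; others in the source may bear on it.

Compound 1, `O=C1/C(=C/c2cccc(Cl)c2)c2ccccc2N1c1c(Cl)cccc1Cl`: 50 ug/mL
Compound 2, `O=C1/C(=C/c2c(Cl)cccc2Cl)c2ccccc2N1c1c(Cl)cccc1Cl`: > 100 ug/mL

In a functional assay on SW-620 cells (Homo sapiens) for cytotoxicity, read by MTT assay, with a stated time of 3 days (on this read-out lower numbers stand for an effect already at smaller amounts and higher numbers for an effect only at larger amounts of compound), compound 1 gives 50 ug/mL. For compound 2 the assay reports only a limit, > 100 ug/mL, as noted in the limit of > 100 ug/mL in this assay, at which 1 of the 2 values shown sits. Among the compounds with values here, the single measured step, an at least 2.0-fold higher number from compound 1 to compound 2 (0.30 log units; that floor lies within the scatter), is therefore known only as a floor. Compound 3, `COc1ccc(/C=C2/C(=O)N(c3c(Cl)cccc3Cl)c3ccccc32)cc1`, carries 4-methoxyphenyl in place of 2,6-dichlorophenyl on a double-bonded chain carbon bound to a double-bonded ring carbon. Within the data shown here, no measured step covers a methoxyphenyl group, so the direction of the change is open; the only comparison shows that the 2,6-dichlorophenyl group sits at the limit. Compound 3 is expected at 70 ug/mL, within 25 ug/mL to 200 ug/mL, an estimated step of an at least 1.4-fold lower number from compound 2 to compound 3 (0.15 log units; that floor lies within the scatter).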

Compound 3, concentration for half-maximal effect: > 100 ug/mL
Compound 3: only a limit was reported (the forecaster's own chance of this, stated with the estimate: 45%); at least 1.4-fold (0.15 log units) between middle value and limit.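

In this assay, a second group on a double-bonded chain carbon bound to a double-bonded ring carbon, 4-methoxyphenyl, now reads only as a limit, as 2,6-dichlorophenyl did: the limit of > 100 ug/mL in this assay, at which 2 of the 3 values shown sit. Replacing 3-chlorophenyl with 4-methoxyphenyl gives an at least 2.0-fold higher number from compound 1 to compound 3 (0.30 log units; that floor lies within the scatter), so this comparison sets only a floor and establishes no clear loss. The step between compound 2 and compound 3 cannot be read, as both values are limits.

As far as these compounds go, it remains open how far above the limit compound 2 and compound 3 lie. From the compounds shown here alone, it also remains open whether an amine or a carboxylic acid on the phenyl ring at this place would give a number clearly lower than that of compound 1.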